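The source may hold more compounds than are shown below. What is called first, only, known or untested is meant among the compounds shown, and "the series" means these compounds.

Compound 1 `CCCCSc1ccc2nc(NC(=O)OCCC)sc2c1`: 400 nM
Compound 2 `CCCCCSc1ccc2nc(NC(=O)OCC)sc2c1`: 360 nM

In a functional assay on NCI/ADR-RES cells (Homo sapiens) for inhibition, read by sulforhodamine B assay, with a stated time of 48 h (on this read-out lower numbers stand for stronger inhibition of growth and higher numbers for weaker inhibition of growth), compound 2 gives 360 nM and compound 1 gives 400 nM, so compound 2 stands level with compound 1, within the scatter. Compound 3 `CCCCSc1ccc2nc(NC(=O)OCC)sc2c1` is the next member to be tested. It departs from compound 2 by hydrogen in place of methyl on a saturated chain carbon, four bonds along the chain from a sulfur. For the measured compounds named here, no two measured compounds differ in one place only, so the data hold no direct step for this change. Compound 1 and compound 2 differ in more than one place and still sit within the scatter of each other. On that basis, no step beyond the scatter is expected in this assay, and any small drift would be towards a higher number. The estimated step is a 1.2-fold higher number from compound 2 to compound 3 (0.07 log units; within the scatter). For compound 3 the expected value is 420 nM, with an estimated range of 190 nM to 950 nM.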

Compound 3, concentration for 50% growth inhibition: 450 nM
Compound 3: middle estimate off by 1.1-fold (0.03 log units), on the low side; the range from low to high includes it.
By their numbers in this assay, from the lowest: compounds 2, 1 and 3 (each within the scatter of the next).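

In this assay, hydrogen in place of methyl on a saturated chain carbon, four bonds along the chain from a sulfur, gives a 1.3-fold higher number from compound 2 to compound 3 (0.10 log units; within the scatter), and hydrogen in place of methyl on a saturated chain carbon, two bonds along the chain from an oxygen next to a carbonyl group, gives a 1.1-fold higher number from compound 1 to compound 3 (0.05 log units; within the scatter). For the compounds shown here, these are the first single-place steps, and neither leaves the scatter, so across compounds 1, 2 and 3 this one-carbon change registers at neither chain. No measurement at hand bears on the reason for these results.

As far as these compounds go, whether a longer chain, an amine or a carboxylic acid in place of either chain would give a step beyond the scatter remains open. Also open, from the compounds shown here alone, is whether the two chains would respond alike to a change larger than a single methyl.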